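This account rests on a few compounds, and the source may have more. Where it says the series, first, only, none or still open, it means among the compounds named here.

Measured in a functional assay on SW480 cells (Homo sapiens) for antiproliferative activity, read by MTT assay, with a stated time of 48 h; a lower number here means a stronger inhibitor, a higher number a weaker inhibitor:
- compound 1 `CCCCCCCCCC(CCO)n1cnc2c(NC)ncnc21` gives 4450 nM
- compound 2 `CCCCCCCCCC(CCO)n1cnc2c(N(C)C)ncnc21` gives 12200 nM
- compound 3 `CCCCCCCCCC(CCO)n1cnc2c(N)ncnc21` gives 6030 nM

Compound 2 has the highest number of the three, which makes it the weakest inhibitor here. Compound 4 `CCCCCCCCCCC(CCO)n1cnc2c(N(C)C)ncnc21` differs from it in one place: methyl in place of hydrogen on a saturated chain carbon, ten or more bonds along the chain from an aromatic nitrogen. The saturated chain simply grows longer, with methyl in place of hydrogen on a saturated chain carbon.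

For the measured compounds named here, no measured step touches this chain, so the data offer only indirect guidance. All three steps change the groups on a nitrogen on an aromatic ring. Two are modest, a 2.7-fold higher number from compound 1 to compound 2 (0.44 log units; beyond the scatter) and a 2.0-fold lower number from compound 2 to compound 3 (0.31 log units; beyond the scatter), while a 1.4-fold higher number from compound 1 to compound 3 (0.13 log units; within the scatter) stays within the scatter. The first of these also puts methyl in place of hydrogen, but at a different place.

With so little to go on, no change beyond the scatter is expected in this assay, and the expected step is a 1.2-fold lower number from compound 2 to compound 4 (0.09 log units; within the scatter). The estimate for compound 4 is 10000 nM, with an expected range from 5000 nM to 20000 nM.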

Compound 4, half-maximal inhibitory concentration: 3320 nM
For compound 4 the middle estimate is 3.0-fold (0.48 log units) above the measured one; the measured number lies below the stated range.
By their numbers in this assay, from the lowest: compounds 4, 1 and 3 (each within the scatter of the next); then compound 2.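

In this assay, methyl in place of hydrogen on a saturated chain carbon, ten or more bonds along the chain from an aromatic nitrogen, gives a 3.7-fold lower number from compound 2 to compound 4 (0.57 log units; beyond the scatter), so the number responds to this chain as well. The earlier compounds shown here varied only the groups on a nitrogen on an aromatic ring, and they could not show that a small extension of the chain alone moves the result beyond the scatter. No measurement shown here explains why this happens.

A single pair cannot show whether a longer chain would lower the number further or whether an amine or a carboxylic acid in place of that methyl would keep the gain. It also leaves open whether the same extension would give a similar step on compound 1 or compound 3.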